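Methyl to ethyl on the saturated chain carbon

The source may report more compounds than this note shows. Statements on the series, on what has been measured and on what is new or still open speak of the compounds shown alone.

Among the compounds with values here, compound 1 `Cc1cn(-c2cc(NC(=O)c3ccc(C)c(Nc4nc(-c5cccnc5)cs4)c3)cc(C(F)(F)F)c2)cn1` gives 28 nM in a functional assay on K562 cells (Homo sapiens) for antiproliferative activity (on this read-out higher numbers stand for weaker inhibition and lower numbers for stronger inhibition), the lowest of the three numbers measured so far. Compound 2 `Cc1ccc(C(=O)Nc2cccc(C(F)(F)F)c2)cc1Nc1nc(-c2cccnc2)cs1` gives 3010 nM in this assay, and compound 3 `Cc1cn(-c2cc(Cl)cc(NC(=O)c3ccc(C)c(Nc4nc(-c5cccnc5)cs4)c3)c2)cn1` gives 812 nM. Both steps away from compound 1 are large and beyond the scatter: a 110-fold higher number from compound 1 to compound 2 (2.03 log units; beyond the scatter) with hydrogen in place of 4-methyl-1H-imidazol-1-yl on an aromatic carbon, and a 29-fold higher number from compound 1 to compound 3 (1.46 log units; beyond the scatter) with chloro in place of trifluoromethyl on an aromatic carbon. Both changes sit on aromatic carbons of the shared core.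

Compound 4 `CCc1ccc(C(=O)Nc2cc(-n3cnc(C)c3)cc(C(F)(F)F)c2)cc1Nc1nc(-c2cccnc2)cs1` carries methyl in place of hydrogen on a saturated chain carbon bound to an aromatic carbon; cut one bond further out, the difference reads methyl to ethyl. Within the data shown here, neither measured step touches a saturated chain carbon, so no step bears directly on this change, and the two steps recorded both concern groups on aromatic carbons that compound 4 keeps unchanged. The addition is a single carbon. The working expectation is a step within the usual scatter or at most a modest loss, so a 1.6-fold higher number from compound 1 to compound 4 (0.21 log units; within the scatter) is the estimated change. Compound 4 is estimated at 45 nM, with a range from 12 nM to 160 nM.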

Compound 4, half-maximal inhibitory concentration: 1600 nM
Estimate against measurement, compound 4: 36-fold (1.55 log units) below, outside the stated range (above it).
By their numbers in this assay, from the lowest: compound 1; then compounds 3, 4 and 2 (each within the scatter of the next, the first and the last beyond it).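

In this assay the saturated chain carbon bound to an aromatic carbon proves far from tolerant: methyl in place of hydrogen there gives a 57-fold higher number from compound 1 to compound 4 (1.76 log units; beyond the scatter) and so counts as a large step. The earlier steps shown here showed sensitivity only at groups on aromatic carbons of the shared core, whereas this one shows that the saturated chain carbon is sensitive as well. The entering group is small, with 1 heavy atom, no ring, 0 hydrogen-bond donors, 0 hydrogen-bond acceptors and no net charge, so a large step here does not need a large change in the structure. Nothing among the data shown accounts for the size of this step.

The compounds shown leave open how the read-out responds to other groups at this place, such as a propyl chain, a cyclopropyl ring or a hydroxymethyl group, and so whether ethyl marks a sharp limit or the start of a gradual trend. They also leave open whether the same methyl-to-ethyl change costs as much on a core carrying chloro in place of trifluoromethyl.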